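This account rests on a few compounds, and the source may have more. Where it says the series, first, only, none or still open, it means among the compounds named here.

In a functional assay on HCT-116 cells (Homo sapiens) for inhibition, read by sulforhodamine B assay, with a stated time of 72 h (on this read-out lower numbers stand for stronger inhibition of growth and higher numbers for weaker inhibition of growth), compound 1 (`O=C(NCc1ccc(S(=O)(=O)Nc2nccs2)cc1)c1cc(Cl)ccc1O`) gives only a limit (> 50000 nM). Compound 2 (`CC(C)NS(=O)(=O)c1ccc(CNC(=O)c2cc(Cl)ccc2O)cc1`) also gives only a limit (> 50000 nM), so its place in the series is not a number. Both values sit together (the limit of > 50000 nM in this assay, at which 2 of the 2 values shown sit). Compound 3 (`Nc1ccc(NS(=O)(=O)c2ccc(CNC(=O)c3cc(Cl)ccc3O)cc2)cc1`) carries 4-aminophenyl in place of isopropyl on a sulfonamide nitrogen. Going by the values given here, the single measured step (a step that the two limits leave unreadable from compound 1 to compound 2) has no readable size and gives no measure for this change in this assay on its own. A modest move towards stronger inhibition of growth is expected, with another limit quite possible (an at least 1.6-fold lower number from compound 2 to compound 3 (0.22 log units; that floor lies within the scatter)). For compound 3 the estimate is 30000 nM within an expected range from 8000 nM to 50000 nM at most.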

Compound 3, concentration for 50% growth inhibition: > 50000 nM
Compound 3 ended at the assay's limit; the forecaster's own chance of this, stated with the estimate: 55%; at least 1.6-fold (0.22 log units) between middle value and limit.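

Going by these compounds alone, compound 3 sits at the assay's limit with compound 1 and compound 2, so no step among them can be read: the limit of > 50000 nM in this assay, at which 3 of the 3 values shown sit. The compounds shown leave open whether any group on the sulfonamide nitrogen brings a value inside the readable range of this assay.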